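Acetoxy addition on two related oxadiazoline-type cores

The source may report more compounds than this note shows. Statements on the series, on what has been measured and on what is new or still open speak of the compounds shown alone.

Measured compounds:
compound 1 `COc1ccc(C2OC(c3cc(OC)c(OC)c(OC)c3)=NN2C(C)=O)cc1`, 57000 nM
compound 2 `COc1ccc(C2OC(c3cc(OC)c(OC)c(OC)c3)=NN2C(C)=O)cc1OC(C)=O`, 3900 nM
compound 3 `COc1ccc(C2=NN(C(C)=O)C(c3ccc(OC)cc3)O2)cc1`, a limit only, > 100000 nM

In a functional assay on L1210 cells (Mus musculus) for antiproliferative activity, read by MTT assay, with a stated time of 72 h (a lower number here means a stronger inhibitor, a higher number a weaker inhibitor), compound 1 gives 57000 nM and compound 2 gives 3900 nM. The change between them is acetoxy in place of hydrogen on an aromatic carbon, and it made a 15-fold lower number from compound 1 to compound 2 (1.16 log units; beyond the scatter). Compound 3 sits at a limit of this assay, (the limit of > 100000 nM in this assay, at which 1 of the 3 values shown sits). How the core of compound 3 differs from the core of compound 1 is not broken down here.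

Compound 4 `COc1ccc(C2=NN(C(C)=O)C(c3ccc(OC)c(OC(C)=O)c3)O2)cc1` is not yet measured. From compound 3 to compound 4 the change is acetoxy in place of hydrogen on an aromatic carbon, the same change as from compound 1 to compound 2. For compound 4 a step of an at least 5.0-fold lower number from compound 3 to compound 4 (0.69 log units; beyond the scatter) is expected, resting on the step from compound 1 to compound 2 and on the limit that compound 3 shows. Compound 4 is estimated at 20000 nM, between 4000 nM and 100000 nM.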

Compound 4, half-maximal inhibitory concentration: > 100000 nM
Compound 4: no number, only a limit (the forecaster's own chance of this, stated with the estimate: 30%); at least 5.0-fold (0.69 log units) between middle value and limit.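

Among these compounds, compound 3 and compound 4 both sit at a limit, not at a number, so no step between them can be read: the limit of > 100000 nM in this assay, at which 2 of the 4 values shown sit.
On these data alone, whether acetoxy in place of hydrogen on an aromatic carbon changes activity on the core of compound 3 remains open.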